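Meta-substituted phenyltriazole quinuclidines: fluoro versus fluoroethoxy

The source may hold more compounds than are shown below. What is called first, only, known or untested is meant among the compounds shown, and "the series" means these compounds.

Measured compounds:
- compound 1, `c1ccc(COc2cccc(-c3cn([C@@H]4CN5CCC4CC5)nn3)c2)cc1`: 6.67 nM
- compound 2, `FCCOc1cccc(-c2cn([C@H]3CN4CCC3CC4)nn2)c1`: 558 nM
- compound 3, `Oc1ccc(-c2cn(C3CN4CCC3CC4)nn2)cc1`: 3.44 nM

All three values come from an assay on HEK293 cells for displacement of a labelled ligand from Neuronal acetylcholine receptor; alpha3/beta4 (Homo sapiens), read by scintillation counting, with a stated time of 120 min; a lower number here means a stronger inhibitor, a higher number a weaker inhibitor. Compound 2 has the highest number of the three. Compound 1, with a benzyloxy group in place of the 2-fluoroethoxy group and the opposite configuration at the quinuclidine carbon, gives 6.67 nM, a gap well beyond the scatter. Compound 3, which carries a hydroxy group on the phenyl ring and is drawn without stereochemistry, gives 3.44 nM, again far below compound 2.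

The next compound, compound 4, `Fc1cccc(-c2cn([C@H]3CN4CCC3CC4)nn2)c1`, keeps the core and configuration of compound 2 and changes only the phenyl substituent: fluoro in place of 2-fluoroethoxy on an aromatic carbon. Within the data shown here, no measured pair in the set shows this particular change, so the direction is open. Given that compound 2 sits alone at the high end with 558 nM, the step to compound 4 is expected to be modest, most likely toward a lower number but possibly within the scatter; the estimated step is a 2.2-fold lower number from compound 2 to compound 4 (0.35 log units; beyond the scatter). Compound 4 is expected to give about 250 nM in this assay, with a plausible range from 50 nM to 1500 nM.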

Compound 4, inhibition constant: 362 nM
For compound 4 the middle estimate is 1.4-fold (0.16 log units) below the measured one; the measured number falls inside the stated range.
By their numbers in this assay, from the lowest: compounds 3 and 1 (each within the scatter of the next); then compounds 4 and 2 (each within the scatter of the next).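

In this assay, among these compounds, the step of a 1.5-fold lower number from compound 2 to compound 4 (0.19 log units; within the scatter) is the only comparison that isolates one place, an aromatic carbon meta to a large group. At this position, with the core and configuration held fixed, the 2-fluoroethoxy chain and a lone fluoro cannot be told apart, even though they differ in size and only the chain carries a hydrogen-bond acceptor. No supporting data bear on why the two groups read alike.

Still open, from the compounds shown here alone, is whether any group at this position gives a step beyond the scatter, for instance an amine, a carboxylic acid or a longer alkoxy chain. Also open, going by these compounds, is whether the exchange of 2-fluoroethoxy for fluoro reads the same with the opposite configuration of the core.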